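A few compounds are considered here, and "the series" means these few. Any claim that something is new, unique, unknown or untested is made for them only; others in the source may bear on it.

Measured in an assay on HEK293 cells for inhibition of N-acylethanolamine-hydrolyzing acid amidase (Rattus norvegicus), read by LC-MS, with a stated time of 30 min; a lower number here means a stronger inhibitor, a higher number a weaker inhibitor:

Compound 1, `O=C(CCCCCCc1ccccc1)N1CCCC1`, gives 12900 nM.
Compound 2, `Cc1ccc(CCCCCCC(=O)N2CCCC2)cc1`, gives 9600 nM.
Compound 3, `O=C(CCCCCCc1ccc(F)cc1)N1CCCC1`, gives 8000 nM.

The three compounds share one core and differ only in the group on the aromatic ring. Compound 3 stands close to both neighbours: the step of a 1.2-fold lower number from compound 2 to compound 3 (0.08 log units; within the scatter) and the step of a 1.6-fold lower number from compound 1 to compound 3 (0.21 log units; within the scatter) both fall within the usual scatter, so the three numbers are, for practical purposes, indistinguishable.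

Compound 4, `O=C(CCCCCCc1ccc(Cl)cc1)N1CCCC1`, has not yet been measured. It differs from compound 3 in one place: chloro in place of fluoro on an aromatic carbon. Within the data shown here, the steps that bear on this change are those in which the same aromatic position was varied: a 1.3-fold lower number from compound 1 to compound 2 (0.13 log units; within the scatter), a 1.6-fold lower number from compound 1 to compound 3 (0.21 log units; within the scatter) and a 1.2-fold lower number from compound 2 to compound 3 (0.08 log units; within the scatter). Each of them stayed within the scatter, whether the group was hydrogen, methyl or fluoro. Exchanging one small group for another at this position is therefore expected to give no step beyond the scatter, a 1.1-fold lower number from compound 3 to compound 4 (0.03 log units; within the scatter). For compound 4 the expected value in this assay is 7500 nM, with a range from 3500 nM to 16000 nM.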

Compound 4, half-maximal inhibitory concentration: 34500 nM
Beside the measured number, compound 4's estimate is 4.6-fold (0.66 log units) below it; measured number above the stated range.
By their numbers in this assay, from the lowest: compounds 3, 2 and 1 (each within the scatter of the next); then compound 4.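

Chloro breaks the earlier picture in this assay with a 4.3-fold higher number from compound 3 to compound 4 (0.63 log units; beyond the scatter) and a 3.6-fold higher number from compound 2 to compound 4 (0.56 log units; beyond the scatter) and a 2.7-fold higher number from compound 1 to compound 4 (0.43 log units; beyond the scatter) and so compound 4 is the weakest of the four inhibitors. The position para to a large group is therefore not indifferent to what sits on it, and hydrogen, methyl and fluoro alone gave no sign of this; even one halogen exchanged for another, with the same count of heavy atoms, donors and acceptors and no net charge, can move the number beyond the scatter. Nothing available explains why chloro departs from the other three groups.

On these data alone, whether bromo, trifluoromethyl or methoxy at this position would follow chloro or stay with the other three remains open. So does whether chloro would have the same effect with a shorter or longer chain.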